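Amide aryl swap in a piperidine sulfonamide series

The compounds below may be only part of what the source reports. "The series", "measured", "known", "first", "only" and "open" are said of these compounds alone.

Measured so far:
- compound 1 `CS(=O)(=O)c1ccc(C(=O)N2CCC(N(C3CC3)S(=O)(=O)c3cccc(C(F)(F)F)c3)CC2)cc1`: "not determined" (no result reported) in an assay on cells for inhibition of Voltage-dependent L-type calcium channel subunit alpha-1C (Homo sapiens), read by FLIPR and calcium flux, tested at 3 uM; on this read-out higher numbers stand for a stronger effect at the one concentration tested and lower numbers for a weaker effect
- compound 2 `CS(=O)(=O)c1cccc(C(=O)N2CCC(N(C3CC3)S(=O)(=O)c3cccc(C(F)(F)F)c3)CC2)c1`: "not determined" (no result reported) in this assay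
- compound 3 `CS(=O)(=O)c1ccc(F)cc1C(=O)N1CCC(N(C2CC2)S(=O)(=O)c2cccc(C(F)(F)F)c2)CC1`: 34%

Among the measured compounds shown here, only compound 3 carries a number; compound 1 and compound 2 share the same core but returned nothing in this assay, so no step between measured compounds can be drawn and compound 3 is simply the single reference point of the set.

Compound 4 `O=C(c1cccc(OC(F)(F)F)c1)N1CCC(N(C2CC2)S(=O)(=O)c2cccc(C(F)(F)F)c2)CC1` keeps the core of compound 3 and differs in one place: 3-(trifluoromethoxy)phenyl in place of 5-fluoro-2-(methylsulfonyl)phenyl on a carbonyl carbon. The group that leaves and the group that enters have the same heavy-atom count, but the entering 3-(trifluoromethoxy)phenyl carries one fewer hydrogen-bond acceptor and no methylsulfonyl.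

For the measured compounds named here, with no step between measured compounds to lean on, the expected step from compound 3 to compound 4 in this assay is estimated as a number 1 percentage points higher from compound 3 to compound 4 (within the scatter), a change not clearly beyond the scatter in either direction. Compound 4 is therefore estimated at 35%, with a range from 10% to 60%, the width reflecting that the reading of compound 3, 34%, is the only anchor.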

Compound 4, a percentage reported as inhibition, at one concentration (the size of the read-out at that concentration, not a potency): 78%
Estimate against measurement, compound 4: 43 percentage points below; the measured number lies above the stated range.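

In this assay, among the compounds shown here, the group on the carbonyl carbon proves able to move the read-out: 3-(trifluoromethoxy)phenyl in place of 5-fluoro-2-(methylsulfonyl)phenyl gives a number 44 percentage points higher from compound 3 to compound 4 (beyond the scatter), the only step in the set that can be read. The change is compound in nature, since the entering group at the same heavy-atom count loses the methylsulfonyl and the ring fluorine, gains trifluoromethoxy and has fewer hydrogen-bond acceptors, and this one step cannot separate these differences. No evidence at hand bears on the reason for the step.

Going by these compounds, whether the gain follows the trifluoromethoxy group or the loss of the methylsulfonyl stays open, as does how an unsubstituted phenyl or a pyridine would read at this place. Steps involving compound 1 and compound 2 cannot be read.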